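The source may hold more compounds than are shown below. What is called first, only, known or untested is meant among the compounds shown, and "the series" means these compounds.

Compound 1 `Cc1ccc(COc2ccc(C(=O)NC(=O)Nc3ccc(C)c(-c4nc5ccccc5[nH]4)c3)cc2)cc1` gives 6360 nM in a functional assay on MNK45 cells (Homo sapiens) for inhibition, read by MTT assay, with a stated time of 48 h; on this read-out lower numbers stand for stronger inhibition and higher numbers for weaker inhibition. Compound 2 `Cc1ccc(NC(=O)NC(=O)c2ccc(OCc3ccc(F)cc3)cc2)cc1-c1nc2ccccc2[nH]1` carries fluoro in place of methyl on an aromatic carbon and gives 240 nM in this assay, a step of a 27-fold lower number from compound 1 to compound 2 (1.42 log units; beyond the scatter). Compound 3 `Cc1ccc(COc2ccc(C(=O)NC(=O)Nc3ccc(Cl)c(-c4nc5ccccc5[nH]4)c3)cc2)cc1` carries chloro in place of methyl on an aromatic carbon relative to compound 1. In this assay compound 3 gives 3190 nM, a step of a 2.0-fold lower number from compound 1 to compound 3 (0.30 log units; within the scatter). For the measured compounds named here, compound 4 `O=C(NC(=O)c1ccc(OCc2ccc(F)cc2)cc1)Nc1ccc(Cl)c(-c2nc3ccccc3[nH]2)c1` is not yet measured in this assay; it carries fluoro in place of methyl on an aromatic carbon relative to compound 3, the same change as the one between compound 1 and compound 2, with the place read identically in both pairs, while the two cores differ in the way already noted for compound 3 against compound 1. A step of a 21-fold lower number from compound 3 to compound 4 (1.33 log units; beyond the scatter) is expected for compound 4, close in size to the one seen before, because a 27-fold lower number from compound 1 to compound 2 (1.42 log units; beyond the scatter) was large and compound 3 starts from 3190 nM. Compound 4 is thus estimated at 150 nM in this assay, expected to lie between 50 nM and 600 nM.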

Compound 4, half-maximal inhibitory concentration: 350 nM
The estimate for compound 4 lay 2.3-fold (0.37 log units) below the measured number; the range from low to high includes it.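

In this assay, fluoro in place of methyl gives a 9.1-fold lower number from compound 3 to compound 4 (0.96 log units; beyond the scatter), the same direction as on the core of compound 1 but a smaller step: the same change on two cores in this assay, a 27-fold lower number (1.42 log units; beyond the scatter) from compound 1 to compound 2 and a 9.1-fold lower number (0.96 log units; beyond the scatter) from compound 3 to compound 4, 2.9-fold (0.46 log units) apart, beyond the scatter of two such steps. Chloro in place of methyl on the other aromatic position gives a 1.5-fold higher number from compound 2 to compound 4 (0.16 log units; within the scatter), and although this step and the earlier one each lie within the scatter, they differ from each other: the same change on two cores in this assay, a 2.0-fold lower number (0.30 log units; within the scatter) from compound 1 to compound 3 and a 1.5-fold higher number (0.16 log units; within the scatter) from compound 2 to compound 4, 2.9-fold (0.46 log units) apart, beyond the scatter of two such steps. The direction of the fluoro change thus held on both cores, but its size did not transfer exactly, and two pairs give no general rule for other cores and no explanation for the difference.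

Still open, on these data alone, is whether a chloro or methoxy group in place of the fluoro would give a similar step. Also open, as far as these compounds go, is how the fluoro change behaves on a core carrying a nitrile in place of the chloro.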